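Chloro to methoxy on the shared core: an expected step

The compounds below may be only part of what the source reports. "The series", "measured", "known", "first", "only" and "open" are said of these compounds alone.

Measured so far:
compound 1 `CCCCNc1ccnc2cc(Cl)ccc12`, in a functional assay on MDA-MB-231 cells (Homo sapiens) for cytotoxicity, read by sulforhodamine B assay, with a stated time of 48 h, in the presence of a further agent that is not named here (on this read-out higher numbers stand for weaker inhibition of growth and lower numbers for stronger inhibition of growth), compound 1 gives 11300 nM
compound 2 `CN(C)CCNc1ccnc2cc(Cl)ccc12`, in this assay compound 2 gives 9880 nM

Compound 2 holds the lower of the two numbers, but the gap to compound 1 is small: a 1.1-fold lower number from compound 1 to compound 2 (0.06 log units; within the scatter). The two values therefore sit within the scatter of each other, and neither can be called the stronger.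

Compound 3 `COc1ccc2c(NCCN(C)C)ccnc2c1` has not yet been measured. It departs from compound 2 at the ring, not at the chain: methoxy in place of chloro on an aromatic carbon. Going by the values given here, the single measured step, the exchange of dimethylamino for ethyl on the saturated chain, concerns a different part of the molecule and gives no direct guidance on a change at the aromatic carbon. Among the compounds with values here, no step that alters the group on the ring has been recorded, so the expectation rests only on the general closeness of the two measured values and on the modest size of the change counted above.

The estimate for compound 3 in this assay is 14000 nM, with a range from 5000 nM to 40000 nM. This estimate means a step of a 1.4-fold higher number from compound 2 to compound 3 (0.15 log units; within the scatter), which is expected to stay within the scatter or just beyond it.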

Compound 3, concentration for 50% growth inhibition: 9450 nM
Estimate against measurement, compound 3: 1.5-fold (0.17 log units) above; the measured number falls inside the stated range.
By their numbers in this assay, from the lowest: compounds 3, 2 and 1 (each within the scatter of the next).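

In this assay, methoxy in place of chloro on an aromatic carbon of the shared core gives a 1.0-fold lower number from compound 2 to compound 3 (0.02 log units; within the scatter) and so leaves the read-out unmoved within the scatter, with the chain of compound 2 held constant. Going by these compounds alone, this is the first measured change at the ring, and it shows that this position, para to a fused ring and meta to a fused ring, can take methoxy, with two heavy atoms and a hydrogen-bond acceptor, in place of the single chlorine without a step beyond the scatter. No measurement that could explain this result is available, and the pair alone gives no reason for it.

On these data alone, whether any group on this aromatic carbon can move the number beyond the scatter remains open, as a primary amine, a carboxylic acid or a phenyl ring there would test a much larger change than this one. Also open is whether methoxy in place of chloro gives a similar step on the chain of compound 1, since the only ring change shown here is on the dimethylamino chain.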